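The compounds below may be only part of what the source reports. "The series", "measured", "known", "first", "only" and "open" are said of these compounds alone.

Working notes on the series. Within the data shown here, in a physicochemical assay for lipophilicity, at pH 7.4 (on this read-out higher numbers stand for higher lipophilicity and lower numbers for lower lipophilicity), compound 2 `Cc1cc(-c2c(C)nn(C)c2C)ccc1-c1nnc(N(C)Cc2ccc3nccn3c2)o1` gives 3.7, the highest of the three numbers so far: compound 1 `Cc1nn(C)c(C)c1-c1ccc(-c2nnc(N(C)Cc3ccc4nccn4c3)o2)c(F)c1` gives 3.2, and compound 3 `Cc1nn(C)c(C)c1-c1ccc(-c2nnc(N(C)Cc3ccc4nccn4c3)o2)c(C#N)c1` gives 2.9. The steps among them are a number 0.50 log units higher from compound 1 to compound 2 (beyond the scatter), a number 0.30 log units lower from compound 1 to compound 3 (within the scatter) and a number 0.80 log units lower from compound 2 to compound 3 (beyond the scatter).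

Compound 4 `Cc1cc(-c2c(C#N)nn(C)c2C)ccc1-c1nnc(N(C)Cc2ccc3nccn3c2)o1` is not yet measured in this assay. It differs from compound 2 by cyano in place of methyl on an aromatic carbon. The closest measured precedent is the step from compound 2 to compound 3, which also exchanges methyl for cyano on an aromatic carbon, though there on the six-membered ring rather than on the five-membered ring; that step was a number 0.80 log units lower from compound 2 to compound 3 (beyond the scatter). The step from compound 1 to compound 3, a number 0.30 log units lower from compound 1 to compound 3 (within the scatter), points the same way but smaller. A drop of roughly the same size as from compound 2 to compound 3 is therefore expected here, so the step from compound 2 to compound 4 is estimated at a number 0.70 log units lower from compound 2 to compound 4 (beyond the scatter). Compound 4 is expected to give about 3, within the range 2.5 to 3.5.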

Compound 4, distribution coefficient: 3.4
Compound 4: middle estimate off by 0.40 log units, on the low side, and the stated range covers the measured number.
By their numbers in this assay, from the lowest: compounds 3, 1, 4 and 2 (each within the scatter of the next, the first and the last beyond it).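

In this assay, cyano in place of methyl on the aromatic carbon of the five-membered aromatic ring with 2 nitrogen, next to the ring nitrogen, does not separate the pair (a number 0.30 log units lower from compound 2 to compound 4 (within the scatter)). Among these compounds, the same exchange on the six-membered ring does separate its pair (a number 0.80 log units lower from compound 2 to compound 3 (beyond the scatter)), so across these two pairs the outcome of this exchange depends on which ring carries it, a difference that only this new pair reveals. Nothing shown gives a measured reason for this difference.

With one exchange at this carbon, the series leaves open how an amine, a carboxylic acid or a longer chain would read there. It also leaves open whether 3-cyano-1,5-dimethyl-1H-pyrazol-4-yl would behave in the same way with fluoro or cyano in place of the methyl on the six-membered ring.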